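Shortening the hydroxycarbamoyl chain of compound 3

The source may report more compounds than this note shows. Statements on the series, on what has been measured and on what is new or still open speak of the compounds shown alone.

Compound 1 `Cc1ccc(-c2cc(C(=O)NCCCCCCC(=O)NO)nn2-c2ccc(S(N)(=O)=O)cc2)cc1`: > 100000 nM (a limit of the assay, not a number)
Compound 2 `COc1ccc2c(c1)c(CC(=O)O)c(C)n2Cc1ccc(-c2cn(CCCCCCC(=O)NO)nn2)cc1`: "not determined" (no result reported)
Compound 3 `COC(=O)Cc1c(C)n(Cc2ccc(-c3cn(CCCCCCCC(=O)NO)nn3)cc2)c2ccc(OC)cc12`: 4430 nM

All three compounds belong to one series tested in a functional assay on A549 cells (Homo sapiens) for inhibition, read by MTT assay, with a stated time of 72 h; a higher number here means a weaker inhibitor, a lower number a stronger inhibitor. Among the measured compounds shown here, compound 3, at 4430 nM, is the only one with an actual number. Compound 1 reached only a limit, > 100000 nM. Compound 2 has no usable result, so it offers no comparison.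

The next compound to be tested is compound 4 `COC(=O)Cc1c(C)n(Cc2ccc(-c3cn(CCCCCC(=O)NO)nn3)cc2)c2ccc(OC)cc12`, which keeps the core of compound 3 and changes only the chain: hydroxycarbamoyl in place of 2-(hydroxycarbamoyl)ethyl on a saturated chain carbon, five bonds along the chain from an aromatic nitrogen. In words, hydroxycarbamoyl stands in place of 2-(hydroxycarbamoyl)ethyl on a saturated chain carbon, five bonds along the chain from an aromatic nitrogen. The chain is therefore shorter, while the hydroxycarbamoyl group at its end stays.

For the measured compounds named here, no measured pair in this small set shows what such a shortening does, so the expectation starts from compound 3 at 4430 nM and remains cautious. In this assay, the expected change is a 1.4-fold higher number from compound 3 to compound 4 (0.13 log units; within the scatter), which stays within the usual scatter and leans slightly toward a weaker value. For compound 4 the estimated value is 6000 nM, with an expected range from 2000 nM to 20000 nM.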

Compound 4, half-maximal inhibitory concentration: 37400 nM
For compound 4 the middle estimate is 6.2-fold (0.79 log units) below the measured one, and the stated range ends below it.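

Replacing 2-(hydroxycarbamoyl)ethyl with hydroxycarbamoyl on this saturated chain carbon, five bonds along the chain from an aromatic nitrogen, gives an 8.4-fold higher number from compound 3 to compound 4 (0.93 log units; beyond the scatter) in this assay. Among the compounds shown here, this is the first comparison here that differs in one place, and it shows that the chain length at this position matters: the shared core and the hydroxycarbamoyl group at the chain end are the same in both compounds, yet the number still rises beyond the scatter. The result for compound 4 is still a true number, so the size of the loss can be read, and only compound 1 stops at a limit of the assay: the limit of > 100000 nM in this assay, at which 1 of the 4 values shown sits.

Going by these compounds, two chain lengths give a direction but no curve, so it remains open whether a longer chain than that of compound 3 would lower the number further or raise it again. On these data alone, it is also open how this shorter chain would behave with a carboxylic acid in place of the methyl ester, or with an amine in place of the hydroxycarbamoyl group at the chain end.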